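A few compounds are considered here, and "the series" means these few. Any claim that something is new, unique, unknown or untested is made for them only; others in the source may bear on it.

Compound 1 `CCOC(=O)NC1CC(C)(C)Oc2ccc(Cl)cc21`: > 100000 nM
Compound 2 `CC1(C)CC(NC(=S)Nc2cccc(C#N)c2)c2cc(Cl)ccc2O1`: 7000 nM
Compound 3 `CC1(C)CC(NC(=S)NCc2ccccc2)c2cc(F)ccc2O1`: 27000 nM

All three share one core and were tested in a functional assay on U-373MG ATCC cells (Homo sapiens) for inhibition, read by MTT assay, with a stated time of 72 h; a higher number here means a weaker inhibitor, a lower number a stronger inhibitor. Compound 2 gives 7000 nM and compound 3 gives 27000 nM. Among the measured compounds shown here, for compound 1 only a limit is known: the value > 100000 nM is the edge of the assay, not a measured number. the limit of > 100000 nM in this assay, at which 1 of the 3 values shown sits, shows that compound 1 sits at this edge, so no numerical step can be measured from it. Compound 4 `CCNC(=O)NC1CC(C)(C)Oc2ccc(Cl)cc21` differs from compound 1 in one place: ethylamino in place of ethoxy on a carbonyl carbon. For the measured compounds named here, no measured pair shows this change, so its size is uncertain; a move into the measurable range is expected, as an at least 1.6-fold lower number from compound 1 to compound 4 (0.22 log units; that floor lies within the scatter). Compound 4 is expected to give about 60000 nM, between 15000 nM and 200000 nM.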

Compound 4, half-maximal inhibitory concentration: > 100000 nM
Compound 4: only a limit was reported; the forecaster's own chance of this, stated with the estimate: 45%; middle value at least 1.6-fold (0.22 log units) away from the limit.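

No step can be read between compound 1 and compound 4, because both stand at the same limit of the assay: the limit of > 100000 nM in this assay, at which 2 of the 4 values shown sit.

The compounds shown leave open how far ethylamino in place of ethoxy on a carbonyl carbon shifts activity.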